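Moving a Fluorine Around a Phenyl Ring

A few compounds are considered here, and "the series" means these few. Any claim that something is new, unique, unknown or untested is made for them only; others in the source may bear on it.

Of the compounds shown here, two of one series have been tested in a functional assay on PC-3 cells (Homo sapiens) for inhibition, read by MTT assay, with a stated time of 72 h; on this read-out higher numbers stand for weaker inhibition and lower numbers for stronger inhibition. Compound 1, `CC(C)n1ncc2c(C(=O)NCc3ccccc3)cccc21`, carries a plain benzyl amide on the shared core; in this assay compound 1 gives 15200 nM. Compound 2, `CC(C)n1ncc2c(C(=O)NCc3cn(-c4ccc(F)cc4)nn3)cccc21`, instead links the amide through a triazole that bears a 4-fluorophenyl group. For compound 2 this assay reports only > 40000 nM, which is a limit of the measurement and not a number. Compound 2 therefore stands at the limit shown in the limit of > 40000 nM in this assay, at which 1 of the 2 values shown sits, and nothing closer can be said of where it truly lies.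

Compound 3, `CC(C)n1ncc2c(C(=O)NCc3cn(-c4ccccc4F)nn3)cccc21`, has not been measured. It differs from compound 2 in one place: 2-fluorophenyl in place of 4-fluorophenyl on an aromatic nitrogen. The two share every atom and differ only in where the fluorine sits on the phenyl ring attached to the triazole nitrogen.

Since no change within the measured pair gives a direct guide, the step from compound 2 is expected to be a step that the limit leaves unreadable from compound 2 to compound 3, which is to say none beyond the usual scatter, with the fluorine shift alone not expected to lift the compound away from the limit. Compound 3 is thus estimated at 50000 nM, within a range from 20000 nM to 150000 nM, and most likely this assay would again return only a limit.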

Compound 3, half-maximal inhibitory concentration: > 40000 nM
Compound 3: no number, only a limit (the forecaster's own chance of this, stated with the estimate: 70%); the middle value lies beyond the limit too.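

In this assay compound 2 and compound 3 both stop at a limit of the measurement and not at a number, so no step can be read between them: the limit of > 40000 nM in this assay, at which 2 of the 3 values shown sit.

Left open is how strongly compound 2 and compound 3 truly inhibit in this assay and whether 2-fluorophenyl in place of 4-fluorophenyl changes that at all.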